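The source may hold more compounds than are shown below. What is called first, only, known or untested is meant among the compounds shown, and "the series" means these compounds.

Measured in a functional assay on HepG2 cells (Homo sapiens) for antiproliferative activity, read by MTT assay, with a stated time of 48 h; on this read-out lower numbers stand for stronger inhibition and higher numbers for weaker inhibition:
- compound 1, `O=[N+]([O-])c1cc(C(F)(F)F)cc([N+](=O)[O-])c1Oc1ccccc1/C=N\OCc1ccccc1`: 1330 nM
- compound 2, `O=[N+]([O-])c1cc(C(F)(F)F)cc([N+](=O)[O-])c1Oc1ccccc1/C=N\OCc1ccccc1F`: 680 nM
- compound 3, `O=[N+]([O-])c1cc(C(F)(F)F)cc([N+](=O)[O-])c1Oc1c(Cl)cc(Cl)cc1/C=N\OCc1ccccc1`: 1120 nM

Compound 1 and compound 2 differ by one change, (fluoro in place of hydrogen on an aromatic carbon). In this assay this gave a 2.0-fold lower number from compound 1 to compound 2 (0.29 log units; within the scatter). Compound 3 carries a different core; the difference between the two cores is not broken down here. Compound 4, `O=[N+]([O-])c1cc(C(F)(F)F)cc([N+](=O)[O-])c1Oc1c(Cl)cc(Cl)cc1/C=N\OCc1ccccc1F`, is not yet measured. It stands to compound 3 as compound 2 stands to compound 1: fluoro in place of hydrogen on an aromatic carbon, the same change at the same kind of place. For the measured compounds named here, with only one earlier example of this change, the expectation for compound 4 rests on it alone: a step of a 1.8-fold lower number from compound 3 to compound 4 (0.26 log units; within the scatter) is expected in this assay, because a 2.0-fold lower number from compound 1 to compound 2 (0.29 log units; within the scatter). Compound 4 is therefore estimated at 620 nM, with a likely range from 300 nM to 1300 nM.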

Compound 4, half-maximal inhibitory concentration: 820 nM
Compound 4: middle estimate off by 1.3-fold (0.12 log units), on the low side; the range from low to high includes it.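

In this assay, fluoro in place of hydrogen on the core of compound 3 gives a 1.4-fold lower number from compound 3 to compound 4 (0.14 log units; within the scatter). Set beside the same change on the core of compound 1, the two steps cannot be told apart in size: the same change on two cores in this assay, a 2.0-fold lower number (0.29 log units; within the scatter) from compound 1 to compound 2 and a 1.4-fold lower number (0.14 log units; within the scatter) from compound 3 to compound 4, 1.4-fold (0.16 log units) apart, within the scatter of two such steps. For the compounds shown here, since each step lies within the scatter, this shows only that these numbers reveal no difference between the two cores for this change; it does not show that the change has a real effect on either core, or that it would carry over to other cores.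

The compounds shown leave open what a chloro, a methoxy or an amine would give in place of the fluoro. They also leave open what a longer chain would give in place of the benzyl.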